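A Second Methyl on the Ring of Compound 2

The compounds below may be only part of what the source reports. "The series", "measured", "known", "first", "only" and "open" are said of these compounds alone.

Measured so far:
compound 1, `Brc1ccccc1OCC1=NCCO1`, 90%
compound 2, `Cc1ccccc1OCC1=NCCO1`, 60%
compound 3, `O=[N+]([O-])c1ccccc1OCC1=NCCO1`, 55%

All three compounds were tested in a toxicity assay on the whole organism with Rattus norvegicus as the target, at a dose of 200 mg/kg by the oral route; on this read-out higher numbers stand for a stronger effect at the one dose given and lower numbers for a weaker effect. Compound 1 gives 90%, compound 2 gives 60% and compound 3 gives 55%. Compound 2 stands second highest of the three numbers: the step of a number 30 percentage points lower from compound 1 to compound 2 (beyond the scatter) is beyond the scatter, while the step of a number 5 percentage points lower from compound 2 to compound 3 (within the scatter) is within it, so compound 2 and compound 3 cannot be told apart on these numbers.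

The unmeasured compound 4, `Cc1ccc(OCC2=NCCO2)c(C)c1`, differs from compound 2 in one place: methyl in place of hydrogen on an aromatic carbon.

For the measured compounds named here, none of the measured steps adds a group to a hydrogen. The steps of a number 30 percentage points lower from compound 1 to compound 2 (beyond the scatter) and a number 35 percentage points lower from compound 1 to compound 3 (beyond the scatter) both exchange one aromatic group for another, and the step of a number 5 percentage points lower from compound 2 to compound 3 (within the scatter) shows that swapping methyl for nitro changes little. Going by the values given here, no step therefore speaks directly to adding a methyl, and nothing in the data points to a particular direction. The expectation is for compound 4 a change of no change at the digits printed from compound 2 to compound 4 (within the scatter) in this assay, that is, no step beyond the scatter. Compound 4 is thus estimated at 60%, with a range from 35% to 85%.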

Compound 4, a percentage reported as activity, at one dose (the size of the read-out at that dose, not a potency): 50%
Beside the measured number, compound 4's estimate is 10 percentage points above it; the measured number falls inside the stated range.
By their numbers in this assay, from the lowest: compounds 4, 3 and 2 (each within the scatter of the next); then compound 1.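

Methyl in place of hydrogen on this aromatic carbon, which is para to a group of 7 heavy atoms and meta to a methyl group, gives in this assay a number 10 percentage points lower from compound 2 to compound 4 (within the scatter), so compound 2 and compound 4 cannot be told apart on this read-out. The earlier steps shown here only exchanged one group for another on a carbon that already carried a group, whereas this step shows that a hydrogen at a different place on the ring can give way to a methyl without a difference beyond the scatter. No measurement at hand offers an explanation for this result.

With methyl as the only group shown at this place, it remains open whether an amine, a carboxylic acid or a longer chain there would also stay within the scatter of compound 2, or would instead give a step beyond it. From the compounds shown here alone, it also remains open whether the same added methyl would leave the number unchanged within the scatter on the bromo compound, compound 1, which stands at 90%.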